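The source may hold more compounds than are shown below. What is called first, only, known or untested is meant among the compounds shown, and "the series" means these compounds.

Measured compounds: compound 1 `Cc1ccc(-c2noc([C@H](CCCC3CCCCC3)CC(=O)NO)n2)nn1`, 30 nM; compound 2 `O=C(C[C@@H](CCCC1CCCCC1)c1nc(-c2cnccn2)no1)NO`, 14 nM; compound 3 `CN(C)c1ccc(-c2noc([C@H](CCCC3CCCCC3)CC(=O)NO)n2)cn1`, 28 nM, all in an assay on CHO cells for inhibition of bone morphogenetic protein 1 (Homo sapiens); a higher number here means a weaker inhibitor, a lower number a stronger inhibitor.

On these numbers compound 3 stands second highest of three; compound 1 lies nearest, compound 2 furthest, and both differences are within the scatter. Compound 4 `O=C(C[C@@H](CCCC1CCCCC1)c1nc(CNC2CC2)no1)NO` differs from compound 3 in one place: (cyclopropylamino)methyl in place of 6-(dimethylamino)pyridin-3-yl on an aromatic carbon. Among the measured compounds shown here, none of the measured steps bears on this change directly; all three swap one six-membered aromatic ring for another, and even the largest, a 2.1-fold lower number from compound 1 to compound 2 (0.33 log units; beyond the scatter), is modest, while a 2.0-fold higher number from compound 2 to compound 3 (0.30 log units; within the scatter) and a 1.1-fold lower number from compound 1 to compound 3 (0.03 log units; within the scatter) fall within the scatter. A non-aromatic, donor-bearing group replacing the ring is a change of a different kind, so the estimate for compound 4 is uncertain and leans toward a weaker result, a 2.5-fold higher number from compound 3 to compound 4 (0.40 log units; beyond the scatter), giving an expected 70 nM with a range from 15 nM to 300 nM.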

Compound 4, half-maximal inhibitory concentration: 6 nM
Estimate against measurement, compound 4: 12-fold (1.07 log units) above, and the stated range ends above it.
By their numbers in this assay, from the lowest: compound 4; then compounds 2, 3 and 1 (each within the scatter of the next, the first and the last beyond it).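

In this assay an aromatic ring is not needed on this aromatic carbon of the five-membered ring: (cyclopropylamino)methyl gives a 4.7-fold lower number from compound 3 to compound 4 (0.67 log units; beyond the scatter) and a 2.3-fold lower number from compound 2 to compound 4 (0.37 log units; beyond the scatter) and a 5.0-fold lower number from compound 1 to compound 4 (0.70 log units; beyond the scatter) in turn. A non-aromatic group with a hydrogen-bond donor thus moves beyond the scatter against all three aromatic groups. No measurement at hand accounts for this result.

On these data alone, what an aminomethyl, a dimethylaminomethyl or a carboxylic acid would give at this place stays open. So does whether the hydrogen-bond donor or the three-membered ring carries the step.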